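Swapping one methoxyphenyl arm for a bromophenyl

The compounds below may be only part of what the source reports. "The series", "measured", "known", "first", "only" and "open" are said of these compounds alone.

Within the data shown here, compound 1 `COc1ccc(/C=C2\CCC/C(=C\c3ccc(OC)cc3)C2=O)cc1` gives 178000 nM in an ADME assay on Vero cells (Chlorocebus sabaeus) for inhibition (a lower number here means that less compound is tolerated, a higher number that more compound is tolerated), the lowest of the two numbers known here. Compound 2 `COc1cccc(/C=C2\CCCCC2=O)c1OC` gives 720000 nM in this assay, and the gap between the two lies beyond the scatter. Compound 3 `COc1ccc(/C=C2\CCC/C(=C\c3cccc(Br)c3)C2=O)cc1` differs from compound 1 by 3-bromophenyl in place of 4-methoxyphenyl on a double-bonded chain carbon bound to a double-bonded ring carbon. Among the measured compounds shown here, no measured pair shows a change of this kind, so nothing in the data fixes its size. A modest step, downward if anywhere, is expected: a 1.5-fold lower number from compound 1 to compound 3 (0.17 log units; within the scatter). Compound 3 is estimated at 120000 nM, within a range of 50000 nM to 300000 nM.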

Compound 3, half-maximal cytotoxic concentration: 30000 nM
Beside the measured number, compound 3's estimate is 4.0-fold (0.60 log units) above it; measured number outside the range, below it.
By their numbers in this assay, from the lowest: compound 3; then compound 1; then compound 2.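

In this assay the exchange of 4-methoxyphenyl for 3-bromophenyl on a double-bonded chain carbon bound to a double-bonded ring carbon gives a 5.9-fold lower number from compound 1 to compound 3 (0.77 log units; beyond the scatter) and so shows that this position responds to a change of its aryl arm. Less compound is tolerated with the bromine-bearing arm. Nothing measured here accounts for this step.

From the compounds shown here alone, since the bromine and the substitution position changed together, it remains open which of the two carries the step. A 4-bromophenyl, a 3-methoxyphenyl or a phenyl ring bearing an amine would separate these readings.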